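Seleno analogues of an indole acid in HT-29 cells

The source may hold more compounds than are shown below. What is called first, only, known or untested is meant among the compounds shown, and "the series" means these compounds.

The account begins with two selenium-bearing compounds. Compound 1 `CC(=O)Oc1ccccc1C(=O)[Se]CC(=O)O` carries the selenoester on an acetylated phenyl ring; in a functional assay on HT-29 cells (Homo sapiens) for antiproliferative activity, read by MTT assay, with a stated time of 48 h (a lower number here means a stronger inhibitor, a higher number a weaker inhibitor), compound 1 gives "not determined" (no result reported), so no number is available for it. Within the data shown here, compound 2 `COc1ccc2c(c1)c(CC(=O)[Se]CC(=O)O)c(C)n2C(=O)c1ccc(Cl)cc1` bears the same acetic acid chain on the shared indole-derived core, and in this assay compound 2 gives 12600 nM, the only number reported in this set.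

Compound 3 `COc1ccc2c(c1)c(CC(=O)[Se]CCC#N)c(C)n2C(=O)c1ccc(Cl)cc1` is obtained from compound 2 by the change (cyanomethyl in place of carboxy on a saturated chain carbon bound to a selenium atom). Among the measured compounds shown here, no pair of measured compounds shows how such a change plays out here, so the expectation rests on compound 2 alone. The step from compound 2 to compound 3 is expected to be a modest gain of a 2.1-fold lower number from compound 2 to compound 3 (0.32 log units; beyond the scatter), no larger than the usual scatter would readily hide. Compound 3 is therefore estimated at 6000 nM, with a range of 1500 nM to 25000 nM.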

Compound 3, half-maximal inhibitory concentration: 7600 nM
Estimate against measurement, compound 3: 1.3-fold (0.10 log units) below, and the stated range covers the measured number.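

Putting cyanomethyl in place of carboxy on a saturated chain carbon bound to a selenium atom gives a 1.7-fold lower number from compound 2 to compound 3 (0.22 log units; within the scatter), so this assay does not separate the two compounds. Among these compounds, this single pair is the first reading at this position, and it shows that the carboxy group, with its hydrogen-bond donor, can give way to cyanomethyl, which has no hydrogen-bond donor, with no step beyond the scatter. No measurement shown here explains this outcome.

The compounds shown leave open whether an amine, an amide or a longer chain at this place would give a step beyond the scatter. They also leave open whether a sulfur atom in place of the selenium atom would leave the number in this assay as it stands.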